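The source may hold more compounds than are shown below. What is called first, only, known or untested is meant among the compounds shown, and "the series" means these compounds.

Measured compounds, all in a functional assay on HepG2 cells (Homo sapiens) for inhibition, read by MTT assay, with a stated time of 72 h; a higher number here means a weaker inhibitor, a lower number a stronger inhibitor:
Compound 1 `CC(O)c1cn(Cc2cc(=O)oc3cc(O)ccc23)nn1` gives > 100000 nM, a limit of the assay.
Compound 2 `O=c1cc(Cn2cc(CCCO)nn2)c2ccc(O)cc2o1` gives > 100000 nM, a limit of the assay.
Compound 3 `O=c1cc(Cn2cc(CCCCO)nn2)c2ccc(O)cc2o1` gives > 100000 nM, a limit of the assay.

Compound 2 stands at the limit of this assay and carries no number; the two further values shown are limits as well. Compound 4 `O=c1cc(Cn2cc(CCc3ccccc3)nn2)c2ccc(O)cc2o1` differs from compound 2 by phenyl in place of hydroxymethyl on a saturated chain carbon, two bonds along the chain from an aromatic carbon. The measured steps give no guidance on this change: a step that the two limits leave unreadable from compound 1 to compound 2, a step that the two limits leave unreadable from compound 1 to compound 3 and a step that the two limits leave unreadable from compound 2 to compound 3 each begin and end at the limit, as the limit of > 100000 nM in this assay, at which 3 of the 3 values shown sit, records, so their sizes are not readable. Whether replacing hydroxymethyl with phenyl moves this assay beyond the scatter therefore cannot be inferred; the expectation rests on the starting point alone. Compound 4 is estimated at 80000 nM, with a range from 15000 nM to 300000 nM. That estimate corresponds to an expected step of an at least 1.2-fold lower number from compound 2 to compound 4 (0.09 log units; that floor lies within the scatter).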

Compound 4, half-maximal inhibitory concentration: 50500 nM
Compound 4: the middle estimate sits 1.6-fold (0.20 log units) above what was measured; measured number inside the range.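

Compound 4 is the only compound shown whose value in this assay is a number and not a limit; the other compounds sit at one: the limit of > 100000 nM in this assay, at which 3 of the 4 values shown sit. Phenyl in place of hydroxymethyl reads as an at least 1.9-fold lower number from compound 2 to compound 4 (0.29 log units; that floor lies within the scatter) and phenyl in place of 2-hydroxyethyl as an at least 1.9-fold lower number from compound 3 to compound 4 (0.29 log units; that floor lies within the scatter) and phenethyl in place of 1-hydroxyethyl as an at least 1.9-fold lower number from compound 1 to compound 4 (0.29 log units; that floor lies within the scatter) with each floor within the scatter, so no step is shown to exceed it. Going by these compounds, this position can therefore carry a group that gives a readable value, while the true size of each step stays unknown.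

Open, on these data alone, is whether that readable value depends on the phenyl ring or would also appear with a cyclohexyl ring or a longer chain ending in phenyl. Also open, as far as these compounds go, is how an amine at the chain end would read in this assay.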